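The compounds below may be only part of what the source reports. "The series", "measured", "known", "first", "only" and "open" are said of these compounds alone.

Measured so far:
compound 1, `CCCS(=O)(=O)Nc1ccc(F)c(C(=O)c2n[nH]c3ncc(-c4cccc(N)c4)cc23)c1F`, 1.6%
compound 2, `CCCS(=O)(=O)Nc1ccc(F)c(C(=O)c2n[nH]c3ncc(-c4ccc(Cl)cc4Cl)cc23)c1F`, 22%
compound 3, `CCCS(=O)(=O)Nc1ccc(F)c(C(=O)c2n[nH]c3ncc(-c4ccc(Cl)c(Cl)c4)cc23)c1F`, 45%

In an assay for binding affinity to dual specificity mitogen-activated protein kinase kinase 4 (Homo sapiens), read by KINOMEscan, tested at 100 nM (on this read-out higher numbers stand for a weaker effect at the one concentration tested and lower numbers for a stronger effect), compound 3 stands highest of the three numbers, meaning the weakest effect at the single concentration tested. Compound 4 is `CCCS(=O)(=O)Nc1ccc(F)c(C(=O)c2n[nH]c3ncc(-c4ccc(S(=O)(=O)NCC)cc4)cc23)c1F`. The change is 4-(ethylsulfamoyl)phenyl in place of 3,4-dichlorophenyl on an aromatic carbon. Going by the values given here, two measured steps bear on it: a number 23 percentage points higher from compound 2 to compound 3 (beyond the scatter) and a number 43.4 percentage points higher from compound 1 to compound 3 (beyond the scatter). Both ran upward toward compound 3, and compound 1, which carries 3-aminophenyl, gives 1.6%, the lowest number. Compound 4 again replaces the 3,4-dichlorophenyl with a substituted phenyl, so a downward step is expected, estimated as a number 33 percentage points lower from compound 3 to compound 4 (beyond the scatter). For compound 4 the expected value in this assay is 12%, within a range from 2% to 35%.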

Compound 4, a percentage reported as activity, at one concentration (the size of the read-out at that concentration, not a potency): 3%
Estimate against measurement, compound 4: 9 percentage points above; the range from low to high includes it.
By their numbers in this assay, from the lowest: compounds 1 and 4 (each within the scatter of the next); then compound 2; then compound 3.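

Putting 4-(ethylsulfamoyl)phenyl in place of the dichlorophenyl groups gives a number 42 percentage points lower from compound 3 to compound 4 (beyond the scatter) and a number 19 percentage points lower from compound 2 to compound 4 (beyond the scatter), so a low number at this position is not confined to the 3-aminophenyl of compound 1. The two non-chlorinated groups cannot be told apart here, with a number 1.4 percentage points higher from compound 1 to compound 4 (within the scatter). Nothing available explains why these groups differ from the dichlorophenyls.

Still open, going by these compounds, is which part of the new group matters, the ethyl chain or the sulfamoyl unit. An unsubstituted sulfamoyl, a longer chain in place of ethyl, or a carboxylic acid on the phenyl could separate these.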